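Pyridazin-3-yl in Place of Cyclohexyl: Compound 2 to Compound 4

The source may hold more compounds than are shown below. What is called first, only, known or untested is meant among the compounds shown, and "the series" means these compounds.

Compound 1, `O=C(CCc1cc(Cl)ccc1NC(=O)c1ccccn1)c1ccccc1`: 4500 nM
Compound 2, `O=C(Nc1ccc(Cl)cc1CN1C(=O)c2ccccc2C1=O)C1CCCCC1`: 1500 nM
Compound 3, `Cc1ccc2c(c1C)C(=O)N(Cc1cc(Cl)ccc1NC(=O)c1ccccn1)C2=O`: 2200 nM

In an assay on CHO cells for positive allosteric modulation of metabotropic glutamate receptor 5 (Homo sapiens), read by FLIPR (on this read-out higher numbers stand for an effect only at larger amounts of compound and lower numbers for an effect already at smaller amounts), compound 2 gives 1500 nM, the lowest of the three numbers. Compound 3 gives 2200 nM, which lies within the scatter of compound 2, so no order between these two can be read. Compound 1 gives 4500 nM, a number beyond the scatter from compound 2; the two structures differ in more than one place, so that gap cannot be tied to any single change.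

Compound 4 `O=C(Nc1ccc(Cl)cc1CN1C(=O)c2ccccc2C1=O)c1cccnn1` differs from compound 2 in one place: pyridazin-3-yl in place of cyclohexyl on a carbonyl carbon. Going by the values given here, no pair among the measured compounds isolates this exchange, so the expectation rests on the spread of the three numbers alone, which is narrow. The step of a 1.7-fold higher number from compound 2 to compound 4 (0.22 log units; within the scatter) is expected to be small, if anything toward a higher number, and within the scatter. Compound 4 is accordingly expected to give about 2500 nM in this assay, with a range from 1000 nM to 6500 nM.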

Compound 4, half-maximal effective concentration: > 100000 nM
Compound 4: only a limit was reported; the forecaster's own chance of this, stated with the estimate: 10%; middle value at least 40-fold (1.60 log units) away from the limit.
By their numbers in this assay, from the lowest: compounds 2 and 3 (each within the scatter of the next); then compound 1. At a limit, above all of these: compound 4.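

In this assay, compound 4 gives > 100000 nM, which is a limit and not a number. The exchange of cyclohexyl for pyridazin-3-yl on this carbonyl carbon, whose other neighbour is an amide-type nitrogen, gives an at least 66-fold higher number from compound 2 to compound 4 (1.82 log units; beyond the scatter), so this single place carries far more weight than the narrow spread of the three earlier compounds could reveal. Both groups count the same number of heavy atoms, so the large step comes with no change in that count, only with a non-aromatic carbon ring giving way to an aromatic ring with two nitrogens and two hydrogen-bond acceptors.

Going by these compounds, it remains open whether the step follows the aromatic ring itself or its ring nitrogens, and a phenyl group on this carbonyl carbon would separate the two. It also remains open how far the true number for compound 4 lies from the reported value, and the step is therefore bounded from one side only: the limit of > 100000 nM in this assay, at which 1 of the 4 values shown sits.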